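Lengthening the Chain of Compound 1 by One Carbon

The source may hold more compounds than are shown below. What is called first, only, known or untested is meant among the compounds shown, and "the series" means these compounds.

In a functional assay on COLO 205 cells (Homo sapiens) for cytotoxicity, read by MTT assay, with a stated time of 24 h (a lower number here means a stronger inhibitor, a higher number a weaker inhibitor), compound 1 `CCCCCCCCCCn1cc(-c2nc3ccccc3cc2CCCC)nn1` reaches only the limit of the assay, > 100 ug/mL, so no number is known for it. Compound 3 `Cc1cc2ccccc2nc1-c1cn(-c2ccc(F)cc2)nn1` likewise sits at a limit, > 100 ug/mL, in this assay. Compound 2 `Cc1cc2ccccc2nc1-c1cn(CCC(F)(F)C(F)(F)C(F)(F)C(F)(F)C(F)(F)C(F)(F)C(F)(F)C(F)(F)F)nn1` is the only one of the three to give a number, 75.8 ug/mL in this assay. Going by the values given here, compound 1 therefore stands at the weak end of what this assay reports, alongside compound 3, and no pair of measured compounds differs in a single place, so no measured step is available (the limit of > 100 ug/mL in this assay, at which 2 of the 3 values shown sit).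

Compound 4 `CCCCCCCCCCn1cc(-c2nc3ccccc3cc2CCCCC)nn1` differs from compound 1 by methyl in place of hydrogen on a saturated chain carbon, four bonds along the chain from an aromatic carbon. Among the compounds with values here, with no measured step to lean on, the change is expected to move the value by no more than the usual scatter, in no particular direction. The step of a number no higher from compound 1 to compound 4 (the limit leaves the size open) is thus expected to be essentially none. For compound 4 the estimate in this assay is 100 ug/mL, with a range from 50 ug/mL to 200 ug/mL, and most likely only a limit will again be reported.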

Compound 4, half-maximal inhibitory concentration: > 100 ug/mL
Compound 4: a limit, no number; the forecaster's own chance of this, stated with the estimate: 75%; the middle value lies on the limit itself.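

In this assay compound 4 gives > 100 ug/mL, a limit and not a number. Compound 1 also sits at a limit, so no step can be read between compound 1 and compound 4: the limit of > 100 ug/mL in this assay, at which 3 of the 4 values shown sit.

The compounds shown leave open whether the added methyl changes cytotoxicity at all, and by how much.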